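Adding a second bromo to the aryl ring of compound 3

The source may hold more compounds than are shown below. What is called first, only, known or untested is meant among the compounds shown, and "the series" means these compounds.

Compound 3 `COc1cc(/C=N/Nc2nc(-c3ccc(F)c(F)c3)cs2)cc(Br)c1OC` gives 21100 nM in a functional assay on A549 cells (Homo sapiens) for inhibition, read by MTT assay, with a stated time of 48 h (on this read-out higher numbers stand for weaker inhibition and lower numbers for stronger inhibition), the second highest of three numbers. Compound 1 `COc1cc(/C=N/Nc2nc(-c3ccc(C(F)(F)F)cc3)cs2)c(Br)c(Br)c1OC` gives 17600 nM and compound 2 `COc1cc(/C=N/Nc2nc(-c3cccc(Br)c3)cs2)cc(Br)c1OC` gives 56000 nM. Within the data shown here, the only single-point step measured, a 2.7-fold lower number from compound 2 to compound 3 (0.42 log units; beyond the scatter), concerns the aryl group on the thiazole, not the change at hand. Compound 4 `COc1cc(/C=N/Nc2nc(-c3ccc(F)c(F)c3)cs2)c(Br)c(Br)c1OC` differs from compound 3 by bromo in place of hydrogen on an aromatic carbon. Among the measured compounds shown here, no measured step isolates this change; compound 1 carries the same two bromo groups but also a different aryl group, and its value sits within the scatter of compound 3. Compound 4 is therefore expected to show a 1.2-fold lower number from compound 3 to compound 4 (0.07 log units; within the scatter), no step beyond the scatter, and is estimated at 18000 nM, within a range of 8000 nM to 45000 nM.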

Compound 4, half-maximal inhibitory concentration: 8380 nM
Compound 4: the middle estimate sits 2.1-fold (0.33 log units) above what was measured; measured number inside the range.
By their numbers in this assay, from the lowest: compound 4; then compounds 1 and 3 (each within the scatter of the next); then compound 2.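

In this assay, among these compounds, the added bromo, ortho to a bromo group, gives a 2.5-fold lower number from compound 3 to compound 4 (0.40 log units; beyond the scatter) and so provides the first single-point reading of this change. With both bromo groups in place, the aryl group still matters: 3,4-difluorophenyl in place of 4-(trifluoromethyl)phenyl gives a 2.1-fold lower number from compound 1 to compound 4 (0.32 log units; beyond the scatter) as a further step beyond the scatter. No evidence is available to explain either step. On these data alone, whether a chloro group or an amine on the same carbon would act like bromo remains open, as does whether the bromo step holds with other aryl groups.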